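Fluoro Added to the Bromophenyl Ring of Compound 3

The compounds below may be only part of what the source reports. "The series", "measured", "known", "first", "only" and "open" are said of these compounds alone.

Compound 1 `O=C(Nc1ccc(Oc2ccnc3[nH]ccc23)cc1)c1nn(-c2ccc(Br)cc2F)ccc1=O` — 17900 nM
Compound 2 `Cn1ccc2c(Oc3ccc(NC(=O)c4nn(-c5ccc(Cl)cc5)ccc4=O)cc3)ccnc21` — > 60000 nM
Compound 3 `Cn1ccc2c(Oc3ccc(NC(=O)c4nn(-c5ccc(Br)cc5)ccc4=O)cc3)ccnc21` — 16300 nM

Of the compounds shown here, three share a common core and have been tested in a functional assay on MCF7 cells (Homo sapiens) for cytotoxicity, read by MTT assay, with a stated time of 72 h; a higher number here means a weaker inhibitor, a lower number a stronger inhibitor. Compound 2 `Cn1ccc2c(Oc3ccc(NC(=O)c4nn(-c5ccc(Cl)cc5)ccc4=O)cc3)ccnc21` reaches only the limit of the assay, > 60000 nM, and no number is reported for it. Compound 3 `Cn1ccc2c(Oc3ccc(NC(=O)c4nn(-c5ccc(Br)cc5)ccc4=O)cc3)ccnc21` gives 16300 nM, which is the lowest of the two numbers shown, while compound 1 `O=C(Nc1ccc(Oc2ccnc3[nH]ccc23)cc1)c1nn(-c2ccc(Br)cc2F)ccc1=O` gives 17900 nM, within the scatter of compound 3. Within the data shown here, the only single-point step measured is an at least 3.6-fold lower number from compound 2 to compound 3 (0.56 log units; beyond the scatter).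

Compound 4 `Cn1ccc2c(Oc3ccc(NC(=O)c4nn(-c5ccc(Br)cc5F)ccc4=O)cc3)ccnc21` has not been measured. It differs from compound 3 by fluoro in place of hydrogen on an aromatic carbon, that is, 4-bromophenyl to 4-bromo-2-fluorophenyl. Among the measured compounds shown here, no measured step covers this exact change; the bromo-for-chloro step from compound 2 to compound 3 concerns a different position and a different group, so it does not bear on it. Compound 1 carries the same fluorine on its bromophenyl ring together with a second difference in the core, and its value and that of compound 3 lie within the scatter of each other. Compound 4 is therefore expected to show a 1.0-fold higher number from compound 3 to compound 4 (0.02 log units; within the scatter), no step beyond the scatter, and its estimate in this assay is 17000 nM (range 7000 nM to 45000 nM).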

Compound 4, half-maximal inhibitory concentration: 19800 nM
Compound 4: the middle estimate sits 1.2-fold (0.07 log units) below what was measured, within the range that was stated.
By their numbers in this assay, from the lowest: compounds 3, 1 and 4 (each within the scatter of the next). At a limit, above all of these: compound 2.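

In this assay, fluoro on the bromophenyl ring, ortho to a large group and meta to the bromo group, can now be read on its own on the shared core: a 1.2-fold higher number from compound 3 to compound 4 (0.08 log units; within the scatter). This shows that at this position the change from 4-bromophenyl to 4-bromo-2-fluorophenyl gives no step beyond the scatter, and the methyl on the aromatic nitrogen, which could not be read apart from the fluoro before, likewise stands alone as a 1.1-fold higher number from compound 1 to compound 4 (0.04 log units; within the scatter). On these data alone, putting 4-bromo-2-fluorophenyl in place of 4-chlorophenyl on the aromatic nitrogen gives an at least 3.0-fold lower number from compound 2 to compound 4 (0.48 log units; beyond the scatter), a step whose full size stays unknown, since its starting value is a limit of the assay and not a number: the limit of > 60000 nM in this assay, at which 1 of the 4 values shown sits.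

What the compounds shown leave open is whether a chloro, a methoxy, an amine or a nitrile in place of this fluoro would also stay within the scatter of compound 3. Also open, as far as these compounds go, are how a longer chain than methyl on the aromatic nitrogen would read, and whether the same fluoro on the 4-chlorophenyl ring of compound 2 would give a number at all.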